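Methyl Added to an Amide Chain: A Small Step Expected

The compounds below may be only part of what the source reports. "The series", "measured", "known", "first", "only" and "open" are said of these compounds alone.

Of the compounds shown here, two sharing one core have been measured so far. Compound 1 `CCNC(=O)c1cc(Oc2cccc(NC(=S)Nc3ccc(F)c(F)c3)c2)ccn1` gives 26300 nM in a functional assay on PC-3 cells (Homo sapiens) for cytotoxicity, read by MTT assay, with a stated time of 48 h; on this read-out higher numbers stand for weaker inhibition and lower numbers for stronger inhibition. Compound 2 `CNC(=O)c1cc(Oc2cccc(NC(=S)Nc3cccc(C(F)(F)F)c3)c2)ccn1` gives 24500 nM in this assay. These two numbers lie within the usual scatter of each other, so neither compound can be called the stronger inhibitor; both sit in the range of weak inhibition. Compound 3 `CCNC(=O)c1cc(Oc2cccc(NC(=S)Nc3cccc(C(F)(F)F)c3)c2)ccn1` has not been measured. It differs from compound 2 in one place: methyl in place of hydrogen on a saturated chain carbon bound to an amide-type nitrogen, which turns the methylcarbamoyl of compound 2 into the ethylcarbamoyl already present in compound 1. For the measured compounds named here, no pair of measured compounds differs only in this way, so nothing yet shows how this change alone moves the number. Compound 1 already carries the ethylcarbamoyl and gives 26300 nM, close to compound 2. The step of a 1.0-fold higher number from compound 2 to compound 3 (0.01 log units; within the scatter) is therefore expected to stay within the scatter. Compound 3 is expected to give 25000 nM, with a likely range from 10000 nM to 60000 nM.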

Compound 3, half-maximal inhibitory concentration: 18300 nM
Estimate against measurement, compound 3: 1.4-fold (0.14 log units) above, within the range that was stated.
By their numbers in this assay, from the lowest: compounds 3, 2 and 1 (each within the scatter of the next).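

In this assay methyl in place of hydrogen on a saturated chain carbon bound to an amide-type nitrogen now has a direct reading (a 1.3-fold lower number from compound 2 to compound 3 (0.13 log units; within the scatter)), so going from methylcarbamoyl to ethylcarbamoyl gives no change that can be told from the scatter. With the ethylcarbamoyl held fixed, the other end of the molecule can also be read alone: 3-(trifluoromethyl)phenyl in place of 3,4-difluorophenyl on an amide-type nitrogen gives a step that is likewise small (a 1.4-fold lower number from compound 1 to compound 3 (0.16 log units; within the scatter)). No measurement at hand explains these values.

The compounds shown cover only the methyl and ethyl chains on this amide. From the compounds shown here alone, whether a longer chain such as propyl or butyl, or a chain ending in an amine or a carboxylic acid, would move the number beyond the scatter remains open.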